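This account rests on a few compounds, and the source may have more. Where it says the series, first, only, none or still open, it means among the compounds named here.

The compounds share the core shown in compound 1 `CCN1CCC(NC(=O)c2cc(Cl)c(N)cc2OC)CC1` and differ only in the group carried on the ring amine nitrogen. In a functional assay on HEK293 cells for agonist activity at 5-hydroxytryptamine receptor 4 (Homo sapiens), read by cAMP accumulation (on this read-out higher numbers stand for an effect only at larger amounts of compound and lower numbers for an effect already at smaller amounts), compound 1 gives 79.4 nM. Compound 2 `COc1cc(N)c(Cl)cc1C(=O)NC1CCN(CCCCCN2C(=O)c3ccccc3C2=O)CC1` gives 5.01 nM in this assay, and compound 3 `COc1cc(N)c(Cl)cc1C(=O)NC1CCN(CCCCCCCCS(=O)(=O)O)CC1` gives 1000 nM, the highest of the three numbers. The step of a 13-fold higher number from compound 1 to compound 3 (1.10 log units; beyond the scatter) and the step of a 200-fold higher number from compound 2 to compound 3 (2.30 log units; beyond the scatter) both place compound 3 well beyond the scatter from each of the other two.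

Compound 4 `COc1cc(N)c(Cl)cc1C(=O)NC1CCN(CCCCCN2CCCCC2)CC1` has not yet been measured in this assay. The change from compound 3 to compound 4 is piperidin-1-yl in place of 3-sulfopropyl on a saturated chain carbon, five bonds along the chain from an amine nitrogen in a ring. Both measured steps bear on it: each shows that the 3-sulfopropyl end of the chain in compound 3 goes with a markedly higher number than either the short ethyl of compound 1 or the ring-bearing chain of compound 2. Removing that group in favour of piperidin-1-yl is therefore expected to move the number in this assay downward, and by a large margin, as a 50-fold lower number from compound 3 to compound 4 (1.70 log units; beyond the scatter). Compound 4 is estimated at 20 nM in this assay, within a range from 4 nM to 100 nM.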

Compound 4, half-maximal effective concentration: 5.01 nM
The estimate for compound 4 lay 4.0-fold (0.60 log units) above the measured number, within the range that was stated.
By their numbers in this assay, from the lowest: compounds 2 and 4 (each within the scatter of the next); then compound 1; then compound 3.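

At the place five bonds along the chain from the amine nitrogen in a ring, the end group alone can carry a very large difference in this assay: piperidin-1-yl in place of 3-sulfopropyl gives a 200-fold lower number from compound 3 to compound 4 (2.30 log units; beyond the scatter). The two ring-bearing ends compared here cannot be told apart, since the step to piperidin-1-yl from the group of 11 heavy atoms in compound 2 reads no change at the digits printed from compound 2 to compound 4 (within the scatter), so among these compounds the six-membered aromatic ring and the two oxygens of that larger group are not needed for a number in this range. Adding 3-(piperidin-1-yl)propyl in place of hydrogen gives a 16-fold lower number from compound 1 to compound 4 (1.20 log units; beyond the scatter), which shows that extending the short ethyl of compound 1 with a ring-bearing chain can lower the number, while compound 3 goes against any reading that chain extension alone does this.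

Going by these compounds, it remains open how a carboxylic acid at the chain end, an open-chain amine such as dimethylamino in place of piperidin-1-yl, or a shorter or longer chain carrying piperidin-1-yl would read here. No measurement given here explains why these end groups differ as they do.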